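From Butoxy to (Trifluoromethyl)sulfanyl: One Change, One Estimate

This account rests on a few compounds, and the source may have more. Where it says the series, first, only, none or still open, it means among the compounds named here.

Compound 1 `CCCCOc1ccc(Nc2nc3nonc3nc2O)cc1` is tested in an assay on mitochondria from L6 cells (Rattus norvegicus) for activation, with a stated time of 90 min (a higher number here means that more compound is needed for the effect, a lower number that less compound is needed), where compound 1 gives 3700 nM. Of the two numbers measured, compound 1 carries the highest, yet compound 2 `Oc1nc2nonc2nc1Nc1cccc(OCc2ccc(C(F)(F)F)cc2)c1` lies within the usual scatter of it, since in this assay compound 2 gives 3000 nM. Among the compounds with values here, no step between measured compounds differing in a single place is available. Compound 3 `Oc1nc2nonc2nc1Nc1ccc(SC(F)(F)F)cc1` differs from compound 1 in one place: (trifluoromethyl)sulfanyl in place of butoxy on an aromatic carbon. Within the data shown here, with no comparable step to lean on, the expected step is a 1.2-fold lower number from compound 1 to compound 3 (0.09 log units; within the scatter), most likely none beyond the scatter. Compound 3 is therefore estimated at 3000 nM, with a range from 1000 nM to 9000 nM.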

Compound 3, half-maximal effective concentration: 1400 nM
Compound 3: middle estimate off by 2.1-fold (0.33 log units), on the high side; low and high end bracket the measured number.
By their numbers in this assay, from the lowest: compound 3; then compounds 2 and 1 (each within the scatter of the next).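

In this assay, (trifluoromethyl)sulfanyl in place of butoxy gives a 2.6-fold lower number from compound 1 to compound 3 (0.42 log units; beyond the scatter) and thus provides the first single-place comparison, showing that the number responds to the group on this aromatic carbon. The two groups have the same heavy-atom count and the same hydrogen-bond acceptor count, so those counts do not separate them, though their atoms differ. Nothing measured here accounts for the step. From the compounds shown here alone, what an amine, a carboxylic acid or a longer chain would do at this place remains open, as does whether the oxygen or the carbon chain of butoxy matters more.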